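The compounds below may be only part of what the source reports. "The series", "measured", "known", "first", "only" and "open" are said of these compounds alone.

Values in a functional assay on BGC-823 cells (Homo sapiens) for antiproliferative activity, read by MTT assay, with a stated time of 48 h (on this read-out lower numbers stand for stronger inhibition and higher numbers for weaker inhibition), are as follows:
- compound 1 (`Clc1ccccc1CSc1nnc(-c2cnccn2)n1-c1ccccc1`) gives 34700 nM here
- compound 2 (`Clc1ccc(CSc2nnc(-c3cnccn3)n2-c2ccccc2)cc1`) gives 27700 nM here

Compound 2 stands level with compound 1, the pair lying within the scatter. Compound 3 (`c1ccc(CSc2nnc(-c3cnccn3)n2-c2ccccc2)cc1`) has hydrogen in place of chloro on an aromatic carbon, para to a large group (hydrogen in place of chloro on an aromatic carbon). For the measured compounds named here, the only measured step, a 1.3-fold lower number from compound 1 to compound 2 (0.10 log units; within the scatter) with 4-chlorophenyl in place of 2-chlorophenyl, stays within the scatter, but it moves the chloro rather than removing it, so it offers only weak guidance. No step beyond the scatter is expected in this assay for this change. The expected step is a 1.2-fold higher number from compound 2 to compound 3 (0.08 log units; within the scatter) by this estimate. Compound 3 is estimated at 33000 nM with an expected range from 15000 nM to 70000 nM in this read-out.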

Compound 3, half-maximal inhibitory concentration: > 50000 nM
Compound 3 was reported as a limit; the forecaster's own chance of this, stated with the estimate: 10%; at least 1.5-fold (0.18 log units) between middle value and limit.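

Compound 3 is held only as a limit in this assay: the limit of > 50000 nM in this assay, at which 1 of the 3 values shown sits. Hydrogen in place of chloro gives an at least 1.8-fold higher number from compound 2 to compound 3 (0.25 log units; that floor lies within the scatter), and the comparison with the 2-chlorophenyl compound gives an at least 1.4-fold higher number from compound 1 to compound 3 (0.15 log units; that floor lies within the scatter). For the compounds shown here, neither floor establishes a real loss, but the chloro-free benzyl is the only compound here without a measured number, so the chloro cannot yet be called dispensable.

On these data alone, the true size of both steps stays open. So does whether a methoxy group or an amine in place of the chloro gives a measurable value.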